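Adding one methyl while the readings sit at a limit

The source may hold more compounds than are shown below. What is called first, only, known or untested is meant among the compounds shown, and "the series" means these compounds.

- Compound 1 `CCCCNc1nc(N)nc2ccn(CC=C(C)C)c12` gives > 24000 nM as a limit
- Compound 2 `CCCCNc1nc(N)nc2ccn(Cc3ccccn3)c12` gives > 24000 nM as a limit

In an ADME assay on HEK293 cells (Homo sapiens) for cytotoxicity, read by ATP content, with a stated time of 6 h (on this read-out higher numbers stand for lower toxicity in this test and lower numbers for higher toxicity in this test), compound 2 gives > 24000 nM as a limit and not as a number. For the measured compounds named here, the only other value, for compound 1, is also a limit, so compound 2 has no readable position relative to it.

Compound 3 `CCCCNc1nc(N)nc2ccn(Cc3cccc(C)n3)c12` differs from compound 2 in one place: methyl in place of hydrogen on an aromatic carbon. In short, a methyl replaces a hydrogen on an aromatic carbon next to the ring nitrogen, turning pyridin-2-yl into 6-methylpyridin-2-yl.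

Going by the values given here, one measured step bears on this change, because it alters the same side group: a step that the two limits leave unreadable from compound 1 to compound 2. It gives no size to build on. The wider picture is the limit of > 24000 nM in this assay, at which 2 of the 2 values shown sit.

A change of one methyl is therefore expected to stay within the scatter in this assay, with no direction predicted. The expected change is a step that the limit leaves unreadable from compound 2 to compound 3 and may well be hidden by another limit. For compound 3 the estimated value is 30000 nM (expected range 15000 nM to 60000 nM) in this test.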

Compound 3, half-maximal cytotoxic concentration: > 24000 nM
Compound 3: a limit, no number; the forecaster's own chance of this, stated with the estimate: 85%; the middle value is on the limit's open side.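

In this assay compound 3 gives > 24000 nM as a limit and not a number. The readings for compound 1 and compound 2 are limits too, and no step among these three compounds can be read. The compounds shown leave open whether any of these side groups changes toxicity in this test at all.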